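The source may hold more compounds than are shown below. What is called first, only, known or untested is meant among the compounds shown, and "the series" means these compounds.

In an ADME assay on MDBK cells (Bos taurus) for cytotoxicity, read by MTT assay, with a stated time of 96 h (on this read-out higher numbers stand for lower toxicity in this test and lower numbers for higher toxicity in this test), three related compounds have been measured. Compound 1 `Fc1ccccc1NC(=S)Nc1cccc(C(F)(F)F)c1` gives only a limit of the assay, > 100000 nM. Compound 2 `CCNC(=S)Nc1cccc(C(F)(F)F)c1` likewise gives only a limit, > 100000 nM. Compound 3 `CC[C@H]1CC[C@H](c2ccc(NC(=S)Nc3cccc(C(F)(F)F)c3)cc2)CC1` gives 9000 nM. Within the data shown here, the one measured step, a step that the two limits leave unreadable from compound 1 to compound 2, therefore cannot be sized. Among the measured compounds shown here, compound 3 thus stands as the only real number among the three. The other two values sit at the limit of > 100000 nM in this assay, at which 2 of the 3 values shown sit.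

Compound 4 `FC(F)(F)c1cccc(NC(=S)Nc2ccc(I)cc2)c1` differs from compound 3 in one place: iodo in place of 4-ethylcyclohexyl on an aromatic carbon. For the measured compounds named here, no measured step covers this kind of change; the single step available concerns a change at an amide-type nitrogen, not at an aromatic carbon, and its size is not readable anyway. Going by the values given here, what remains is the simple picture that compound 3, the one carrying the 4-ethylcyclohexyl group, is the only compound giving a number, whereas the two compounds without it stop at a limit. Compound 4, which loses that group and gains iodo, is therefore expected to move back toward the limit, by an estimated 4.4-fold higher number from compound 3 to compound 4 (0.65 log units; beyond the scatter). For compound 4 the half-maximal cytotoxic concentration is estimated at 40000 nM, within a range from 10000 nM to 100000 nM, with a real chance that only a limit is reported.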

Compound 4, half-maximal cytotoxic concentration: 9500 nM
Beside the measured number, compound 4's estimate is 4.2-fold (0.62 log units) above it; measured number below the stated range.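

In this assay, the step at this aromatic carbon, para to a large group, reads a 1.1-fold higher number from compound 3 to compound 4 (0.02 log units; within the scatter). Among these compounds, a single iodine atom and a 4-ethylcyclohexyl group of 8 heavy atoms, with its ring and 2 defined stereocentres, therefore cannot be told apart in this test, and compound 3 is no longer the only compound that gives a real number. With 4-iodophenyl on the amide-type nitrogen, the comparisons read an at least 10-fold lower number from compound 2 to compound 4 (1.02 log units; beyond the scatter) and an at least 10-fold lower number from compound 1 to compound 4 (1.02 log units; beyond the scatter), and the sizes of both steps are bounded only, since compounds 1 and 2 each stop at a limit: the limit of > 100000 nM in this assay, at which 2 of the 4 values shown sit.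

Two groups at this aromatic carbon cannot show whether the substituent's size matters at all here, or whether a small group such as methyl, or a methoxy, an amine or a carboxylic acid in the same place, would also give a number of this order. As far as these compounds go, how far compounds 1 and 2 truly lie from compound 4 also stays open, as their limits give no real number to set against it.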